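Removing the para-fluorine from compound 3's anilino group

This account rests on a few compounds, and the source may have more. Where it says the series, first, only, none or still open, it means among the compounds named here.

Compound 3 `O=C(CCCCCCn1cc(Nc2ncc(Cl)c(Nc3ccc(F)cc3)n2)cn1)NO` gives 120 nM in a functional assay on Jurkat cells (Homo sapiens) for antiproliferative activity, read by MTT assay, with a stated time of 48 h (on this read-out higher numbers stand for weaker inhibition and lower numbers for stronger inhibition), the second highest of the three numbers recorded. Its nearest neighbour is compound 1 `CNc1nc(Nc2cnn(CCCCCCC(=O)NO)c2)ncc1Cl`, which in this assay gives 70 nM; the step of a 1.7-fold higher number from compound 1 to compound 3 (0.23 log units; within the scatter) lies within the scatter. The furthest is compound 2 `O=C(CCCCCn1cc(Nc2ncc(Cl)c(Nc3ccccc3Cl)n2)cn1)NO`, which gives 310 nM in this assay, beyond the scatter from compound 3. Compound 4 `O=C(CCCCCCn1cc(Nc2ncc(Cl)c(Nc3ccccc3)n2)cn1)NO` differs from compound 3 by hydrogen in place of fluoro on an aromatic carbon. Among the compounds with values here, no measured step bears directly on this change; the only measured step, from methyl to 4-fluorophenyl, was within the scatter, so no movement beyond the scatter is expected. Compound 4 is therefore estimated at 130 nM, between 60 nM and 280 nM, an expected step of a 1.1-fold higher number from compound 3 to compound 4 (0.03 log units; within the scatter).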

Compound 4, half-maximal inhibitory concentration: 90 nM
For compound 4 the middle estimate is 1.4-fold (0.16 log units) above the measured one; the measured number falls inside the stated range.
By their numbers in this assay, from the lowest: compounds 1, 4 and 3 (each within the scatter of the next); then compound 2.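

In this assay, taking the fluoro off the 4-fluorophenyl group leaves the number within the scatter, with a 1.3-fold lower number from compound 3 to compound 4 (0.12 log units; within the scatter), so at this position hydrogen and fluoro cannot be told apart. Phenyl in place of methyl on the nitrogen also stays within the scatter, with a 1.3-fold higher number from compound 1 to compound 4 (0.11 log units; within the scatter), as the step to 4-fluorophenyl did. Nothing available explains either result.

The compounds shown leave open whether a methoxy group or an amine at this position would move the number beyond the scatter. They also leave open whether a carboxylic acid in place of the hydroxamic acid end of the chain would do so.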